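Nitro for Ethyl on a Kinase-Inhibiting Benzamide

The source may report more compounds than this note shows. Statements on the series, on what has been measured and on what is new or still open speak of the compounds shown alone.

Of the compounds shown here, two have been measured in an assay on isolated protein for inhibition of Rho-associated protein kinase 2 (Homo sapiens), read by scintillation counting, radiometric assay and 33P incorporation, with a stated time of 40 min, in the presence of a further agent that is not named here; on this read-out higher numbers stand for weaker inhibition and lower numbers for stronger inhibition. Compound 1 `COc1cc(OCC(=O)Nc2cccc(NC(=O)c3ccc(N(C)C)cc3)c2)ccc1C=O` gives 306 nM, and compound 2 `CCc1ccc(C(=O)Nc2cccc(NC(=O)COc3ccc4c(=O)ccoc4c3)c2)cc1` gives 24 nM, the lower of the two numbers and well beyond the scatter from compound 1. Compound 3 `O=C(COc1ccc2c(=O)ccoc2c1)Nc1cccc(NC(=O)c2ccc([N+](=O)[O-])cc2)c1` has not yet been measured; it differs from compound 2 by nitro in place of ethyl on an aromatic carbon. Among the compounds with values here, no measured pair shows this change, so the step is expected to be modest, a 1.7-fold higher number from compound 2 to compound 3 (0.22 log units; within the scatter), at most a little upward. Compound 3 is therefore expected to give about 40 nM, estimated between 12 nM and 130 nM.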

Compound 3, half-maximal inhibitory concentration: 15 nM
For compound 3 the middle estimate is 2.7-fold (0.43 log units) above the measured one; low and high end bracket the measured number.
By their numbers in this assay, from the lowest: compounds 3 and 2 (each within the scatter of the next); then compound 1.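

Nitro in place of ethyl, on an aromatic carbon para to a large group, gives a step within the scatter (a 1.6-fold lower number from compound 2 to compound 3 (0.20 log units; within the scatter)), so 4-ethylphenyl and 4-nitrophenyl cannot be told apart here. Within the data shown here, this position therefore accepts a group with two hydrogen-bond acceptors as readily as one with none, and the earlier compounds offered no such pair. Nothing measured here accounts for this outcome.

Still open, as far as these compounds go, is what a carboxylic acid, a primary amine or a longer chain on this carbon would give. Whether nitro and ethyl also match on the core of compound 1 is open as well.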